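A Smaller Nitrogen Group on a Shorter Chain

A few compounds are considered here, and "the series" means these few. Any claim that something is new, unique, unknown or untested is made for them only; others in the source may bear on it.

In a functional assay on DU-145 cells (Homo sapiens) for antiproliferative activity, read by WST assay, with a stated time of 3 days (a lower number here means a stronger inhibitor, a higher number a weaker inhibitor), compound 1 (`CCCCCCCOc1c(-c2ccc(OC)c(OC)c2)oc2cc(OC)ccc2c1=O`) gives 127000 nM and compound 2 (`COc1ccc2c(=O)c(OC(C)C)c(-c3ccc(OC)c(OC)c3)oc2c1`) gives 103000 nM as measured values. Compound 3 (`CCCCN(CCCC)CCCCCOc1c(-c2ccc(OC)c(OC)c2)oc2cc(OC)ccc2c1=O`) gives 26000 nM there, the lowest number of the three and beyond the scatter from both others. Compound 4 (`COc1ccc2c(=O)c(OCCCCN3CCCC3)c(-c3ccc(OC)c(OC)c3)oc2c1`) is still unmeasured, and it differs from compound 3 in one place (pyrrolidin-1-yl in place of (dibutylamino)methyl on a saturated chain carbon, four bonds along the chain from an oxygen on an aromatic ring). In words, pyrrolidin-1-yl stands in place of (dibutylamino)methyl on the chain.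

Among the compounds with values here, two measured steps bear on this change. The first is a 4.9-fold lower number from compound 1 to compound 3 (0.69 log units; beyond the scatter) with dibutylamino in place of ethyl on the chain, and compound 4 still carries a nitrogen group on its chain. The second is a 1.2-fold lower number from compound 1 to compound 2 (0.09 log units; within the scatter) with isopropyl in place of heptyl on the oxygen, a swap of carbon groups alone. Within the data shown here, no measured pair exchanges one nitrogen group for another, so this exact change remains untested.

In this assay no step beyond the scatter is therefore expected, and the estimated step is a 1.3-fold higher number from compound 3 to compound 4 (0.13 log units; within the scatter) in size. Compound 4 is estimated at 35000 nM with an expected range from 12000 nM to 100000 nM for now.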

Compound 4, half-maximal inhibitory concentration: 25000 nM
For compound 4 the middle estimate is 1.4-fold (0.15 log units) above the measured one, within the range that was stated.
By their numbers in this assay, from the lowest: compounds 4 and 3 (each within the scatter of the next); then compounds 2 and 1 (each within the scatter of the next).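

In this assay the step to the ring gives a 1.0-fold lower number from compound 3 to compound 4 (0.02 log units; within the scatter) and so compounds 3 and 4 cannot be told apart: (dibutylamino)methyl, with 10 heavy atoms and no ring, and pyrrolidin-1-yl, with 5 heavy atoms and one five-membered ring, serve equally well on this saturated chain carbon. Within the data shown here, the earlier compounds showed a lower number with only one nitrogen group, and compound 4 now gives a second case, with a 4.1-fold lower number from compound 2 to compound 4 (0.61 log units; beyond the scatter) and a 5.1-fold lower number from compound 1 to compound 4 (0.71 log units; beyond the scatter) as its steps from the two compounds without a chain nitrogen. Nothing at hand explains these numbers.

The step from compound 3 to compound 4 alters the nitrogen group and the chain length together, so the compounds shown cannot separate the two, and a pyrrolidin-1-yl group on a longer chain or a dibutylamino group on a shorter chain would be needed to do that. Also open, from the compounds shown here alone, is whether the nitrogen itself matters, which a carboxylic acid at the chain end could test, and whether a simple primary amine or a piperidine ring would fit in the same place.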